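This account rests on a few compounds, and the source may have more. Where it says the series, first, only, none or still open, it means among the compounds named here.

Measured so far:
- compound 1, `COc1cc(-n2ncnc2-c2ccc(C)cc2)cc(OC)c1OC`: 300 nM
- compound 2, `COc1cc(-n2ncnc2-c2cccc(F)c2)cc(OC)c1OC`: > 10000 nM
- compound 3, `COc1cc(-n2ncnc2-c2ccc(Cl)cc2)cc(OC)c1OC`: > 10000 nM

Of the compounds shown here, three sharing one core have been tested in a functional assay on Jurkat cells (Homo sapiens) for antiproliferative activity, read by MTT assay, with a stated time of 72 h; on this read-out lower numbers stand for stronger inhibition and higher numbers for weaker inhibition. Compound 1 gives 300 nM in this assay. For compound 2 the value > 10000 nM is a limit of this assay and not a number. For compound 3 the value > 10000 nM is likewise a limit, so compound 3 sits at the weak end of what this assay reports, together with compound 2 (the limit of > 10000 nM in this assay, at which 2 of the 3 values shown sit). The step of an at least 33-fold higher number from compound 1 to compound 3 (1.52 log units; beyond the scatter) is large, and the step of an at least 33-fold higher number from compound 1 to compound 2 (1.52 log units; beyond the scatter) is of the same size. The step that the two limits leave unreadable from compound 2 to compound 3 cannot be read.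

Compound 4, `COc1cc(-n2ncnc2-c2ccc(SC)cc2)cc(OC)c1OC`, is not yet measured. It differs from compound 3 as follows: methylsulfanyl in place of chloro on an aromatic carbon. Within the data shown here, the only measured steps at this position are those from compound 1 to compound 3 and from compound 1 to compound 2, both large; neither tells directly how methylsulfanyl will behave. Because compound 1 gives 300 nM and methylsulfanyl stands closer to its methyl than to chloro, compound 4 is expected to move back toward stronger inhibition, with a step of an at least 6.6-fold lower number from compound 3 to compound 4 (0.82 log units; beyond the scatter) expected. The estimate for compound 4 in this assay is 1500 nM, within a range from 200 nM to 10000 nM.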

Compound 4, half-maximal inhibitory concentration: 50 nM
The estimate for compound 4 lay 30-fold (1.48 log units) above the measured number; the whole stated range lies above it.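

In this assay, the place para to a large group proves able to carry stronger inhibition than compound 1 showed, since methylsulfanyl in place of methyl gives a 6.0-fold lower number from compound 1 to compound 4 (0.78 log units; beyond the scatter), a modest step beyond the scatter. The same group in place of chloro gives an at least 200-fold lower number from compound 3 to compound 4 (2.30 log units; beyond the scatter), and 4-(methylsulfanyl)phenyl in place of 3-fluorophenyl gives an at least 200-fold lower number from compound 2 to compound 4 (2.30 log units; beyond the scatter), so this one position spans the whole range of values shown. Among these compounds, both of these larger steps start from a limit of the assay and not from a number, and where the earlier compounds showed only that activity could be lost through a change here, compound 4 shows that it can also be gained: the limit of > 10000 nM in this assay, at which 2 of the 4 values shown sit.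

Going by these compounds, how an ethyl, a methoxy or a methylsulfonyl group would behave at this place stays open, and so does whether the gain goes with the sulfur atom or with the longer group as a whole. Compound 2 also differs from the others in both its halogen and where it sits, so the compounds shown cannot separate those two changes, which a 4-fluorophenyl group would begin to do.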